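This account rests on a few compounds, and the source may have more. Where it says the series, first, only, none or still open, it means among the compounds named here.

Compound 1 `CCO/N=C/Nc1cc(Cl)c(OCC#N)c(Cl)c1`: 3.1
Compound 2 `C#CCc1c(Cl)cc(N/C=N/OCC=C)cc1Cl`: 3.7

In a physicochemical assay for lipophilicity, measured as octanol-water partition (on this read-out lower numbers stand for lower lipophilicity and higher numbers for higher lipophilicity), compound 2 gives the higher of the two numbers shown, and the gap down to compound 1 lies beyond the scatter. Compound 3 `C#CCc1c(Cl)cc(N/C=N/OC/C=C/Cl)cc1Cl` has not been measured in this assay. It differs from compound 2 in one place: 2-chloroethenyl in place of vinyl on a saturated chain carbon bound to an oxygen. Within the data shown here, no measured pair shows this change, so the expectation rests on the change alone. In this assay the estimated step of a number 0.60 log units higher from compound 2 to compound 3 (beyond the scatter) is upward and beyond the scatter. Compound 3 is therefore expected to give 4.3, with a range from 3.9 to 4.7.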

Compound 3, partition coefficient: 3.9
The estimate for compound 3 lay 0.40 log units above the measured number; low and high end bracket the measured number.
By their numbers in this assay, from the lowest: compound 1; then compounds 2 and 3 (each within the scatter of the next).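

Swapping vinyl for 2-chloroethenyl on a saturated chain carbon bound to an oxygen gives a number 0.20 log units higher from compound 2 to compound 3 (within the scatter) in this assay and is the first one-place change that can be read in this series. At this position, the added chlorine of 2-chloroethenyl leaves compound 2 and compound 3 within the scatter of each other. No measurement shown bears on why this is so. Still open, from the compounds shown here alone, is how an amine, a carboxylic acid or a longer chain would read at this place, and whether 2-chloroethenyl gives a similar step on another core.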